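The source may hold more compounds than are shown below. What is called first, only, known or untested is meant among the compounds shown, and "the series" means these compounds.

Compound 1 `COc1cc(-c2cc(/C=C/C(=O)c3ccc(N)cc3)[nH]n2)cc(OC)c1OC`: -97%
Compound 2 `COc1ccc(-c2cc(/C=C/C(=O)c3ccc(OC)c(OC)c3)[nH]n2)cc1`: -99%
Compound 3 `COc1cc(-c2cc(/C=C/C(=O)c3ccc(Cl)c(Cl)c3)[nH]n2)cc(OC)c1OC`: -53%

In a functional assay on BT-549 cells (Homo sapiens) for cytotoxicity, read by sulforhodamine B assay, with a stated time of 48 h, tested at 100 uM (a higher number here means a weaker effect of the compound at the concentration tested, a lower number a stronger effect), compound 1 gives -97%, the second highest of the three numbers. Compound 2 sits within the scatter of it, so the two cannot be told apart, while compound 3 stands well away from both. For the measured compounds named here, the only step between compounds that differ in one place is a number 44 percentage points higher from compound 1 to compound 3 (beyond the scatter), a large change that comes from exchanging the group on the carbonyl carbon.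

Compound 4 `COc1ccc(-c2cc(/C=C/C(=O)c3ccc(N)cc3)[nH]n2)cc1OC` differs from compound 1 in a different part of the molecule: hydrogen in place of methoxy on an aromatic carbon. Going by the values given here, no measured step touches this ring, so the step from compound 1 to compound 3 does not bear directly on it. What the data do offer is compound 2, whose rings carry fewer methoxy groups in another pattern and which still gives -99%, within the scatter of compound 1. Taking that together with the unchanged 4-aminophenyl on the carbonyl carbon, the step expected here is a number 4 percentage points higher from compound 1 to compound 4 (within the scatter), none beyond the scatter. Compound 4 is therefore estimated at -93%, with a range from -100% to -70%.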

Compound 4, a percentage reported as activity, at one concentration (the size of the read-out at that concentration, not a potency): -98%
Estimate against measurement, compound 4: 5 percentage points above; the range from low to high includes it.
By their numbers in this assay, from the lowest: compounds 2, 4 and 1 (each within the scatter of the next); then compound 3.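

In this assay, hydrogen in place of methoxy on this aromatic carbon gives a number 1 percentage points lower from compound 1 to compound 4 (within the scatter), so with the 4-aminophenyl on the carbonyl carbon kept, this methoxy group can be lost without the read-out moving beyond the scatter. This is the first step among the compounds shown that touches this ring, and it stands apart from the exchange on the carbonyl carbon (a number 44 percentage points higher from compound 1 to compound 3 (beyond the scatter)), the only step here that goes beyond the scatter. No measurement is available that would explain either outcome, and this single-concentration read-out says nothing about potency.

Going by these compounds, it remains open whether hydrogen would be equally well accepted at this position with 3,4-dichlorophenyl on the carbonyl carbon, the setting in which compound 3 gives -53% and the read-out lies well away from the other compounds. Also open, on these data alone, is whether a hydroxy group, an ethoxy group or a fluorine atom on this aromatic carbon would match hydrogen and methoxy, and whether the other methoxy group on the ring could be exchanged as well.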